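A few compounds are considered here, and "the series" means these few. Any claim that something is new, unique, unknown or untested is made for them only; others in the source may bear on it.

Measured compounds:
compound 1, `COc1cc(-c2nnc(SCC(=O)Nc3ccc(/C(C)=N/O)cc3)n2-c2ccccc2)cc(OC)c1OC`: 70%
compound 2, `COc1ccc(-c2nnc(SCC(=O)Nc3ccc(/C(C)=N/O)cc3)n2-c2ccccc2)cc1`: 58%

In a functional assay on the whole organism (strain albino) for inhibition, with Rattus norvegicus as the target, read by paw edema, with stated times of 30 min and 5 h, at a dose of 0.28 mmol/kg by the oral route (on this read-out lower numbers stand for less inhibition and higher numbers for more inhibition at the one dose given (going by the name of the read-out)), compound 1 gives 70%, and compound 2 gives 58%. Within the data shown here, compound 2 thus stands lowest of the two numbers measured so far, and the only step known is a number 12 percentage points lower from compound 1 to compound 2 (beyond the scatter), where 4-methoxyphenyl took the place of 3,4,5-trimethoxyphenyl.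

Compound 3, `COc1ccc(-c2nnc(SCC(=O)Nc3ccc(/C(C)=N/O)cc3)n2-c2ccccc2)cc1OC`, differs from compound 2 by methoxy in place of hydrogen on an aromatic carbon. This change puts back one of the two methoxy groups that compound 1 carries and compound 2 lacks, so the step from compound 1 to compound 2 is the one that bears on it. Since that step was modest and compound 3 sits partway between the two measured compounds, a rise smaller than a number 12 percentage points lower from compound 1 to compound 2 (beyond the scatter) is expected, likely near the edge of the scatter. Compound 3 is therefore estimated at 64%, in the range 54% to 74%, an expected step of a number 6 percentage points higher from compound 2 to compound 3 (within the scatter).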

Compound 3, a percentage reported as inhibition, in the whole organism at one dose (the size of the read-out at that dose, not a potency): 76%
Compound 3: middle estimate off by 12 percentage points, on the low side, outside the stated range (above it).
By their numbers in this assay, from the lowest: compound 2; then compounds 1 and 3 (each within the scatter of the next).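

In this assay, the change from 4-methoxyphenyl to 3,4-dimethoxyphenyl, with methoxy in place of hydrogen on an aromatic carbon ortho to a methoxy group, gives a number 18 percentage points higher from compound 2 to compound 3 (beyond the scatter), so a single methoxy at this position is enough to carry a step beyond the scatter. The 3,4,5-trimethoxyphenyl and 3,4-dimethoxyphenyl compounds cannot be told apart, with hydrogen in place of methoxy giving a number 6 percentage points higher from compound 1 to compound 3 (within the scatter), so the further methoxy of compound 1 shows no effect that can be read in this series. Nothing available here accounts for why this position matters.

From the compounds shown here alone, it remains open whether the rise at this position is particular to methoxy or would also appear with a hydroxy group, a chlorine atom or a longer ethoxy chain. Going by these compounds, it is also open whether methoxy on this carbon would give the same rise without the methoxy group ortho to it.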